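Changing the Aryl Group on the Amide-Type Nitrogen

The source may report more compounds than this note shows. Statements on the series, on what has been measured and on what is new or still open speak of the compounds shown alone.

Measured compounds:
Compound 1 `O=C(Nc1cccc(-n2cc(-c3ccncc3)c(-c3ccc(Cl)c(O)c3)n2)c1)Nc1ccc(Cl)c(Cl)c1` gives > 32500 nM in a functional assay on UO-31 cells (Homo sapiens) for inhibition, read by sulforhodamine B assay, with a stated time of 48 h; on this read-out lower numbers stand for stronger inhibition of growth and higher numbers for weaker inhibition of growth; this is a limit of the assay, not a number.
Compound 2 `COc1cc(-c2nn(-c3cccc(NC(=O)c4cccc(C(F)(F)F)c4)c3)cc2-c2ccncc2)ccc1Cl` gives > 50000 nM in this assay; this too is a limit.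
Compound 3 `COc1cc(-c2nn(-c3cccc(NC(=O)Nc4ccc(Cl)c(C(F)(F)F)c4)c3)cc2-c2ccncc2)ccc1Cl` gives 4100 nM in this assay.

Compound 1 thus stands only at a limit (the limit of > 32500 nM in this assay, at which 1 of the 3 values shown sits), so its true value is not known beyond that. Compound 4 `O=C(Nc1cccc(-n2cc(-c3ccncc3)c(-c3ccc(Cl)c(O)c3)n2)c1)Nc1cccc(C(F)(F)F)c1` is not yet measured. It differs from compound 1 in one place: 3-(trifluoromethyl)phenyl in place of 3,4-dichlorophenyl on an amide-type nitrogen. Among the measured compounds shown here, no measured step tests this same exchange. For the measured compounds named here, the only measured step, an at least 12-fold lower number from compound 2 to compound 3 (1.08 log units; beyond the scatter), changes the group on the carbonyl carbon and was large, but it also brings a different aryl group and a different core than compound 4, so it gives no direct guide. Because compound 1 sits at a limit (the limit of > 32500 nM in this assay, at which 1 of the 3 values shown sits), only a loose estimate is possible. The step from compound 1 is expected, loosely, to be an at least 1.6-fold lower number from compound 1 to compound 4 (0.21 log units; that floor lies within the scatter). Compound 4 is expected to give about 20000 nM in this assay, with a range from 4000 nM to 80000 nM.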

Compound 4, concentration for total growth inhibition: > 32500 nM
Compound 4: no number, only a limit; the forecaster's own chance of this, stated with the estimate: 50%; middle value at least 1.6-fold (0.21 log units) away from the limit.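

Compound 4, like compound 1, gives only a limit and not a number, so the step between these two compounds cannot be read: the limit of > 32500 nM in this assay, at which 2 of the 4 values shown sit.

The compounds shown leave open whether 3-(trifluoromethyl)phenyl or 3,4-dichlorophenyl on the amide-type nitrogen gives stronger inhibition of growth.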